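Methylation of a Phenolic Oxygen in Two Amide Series

The source may report more compounds than this note shows. Statements on the series, on what has been measured and on what is new or still open speak of the compounds shown alone.

Compound 1 `COc1ccccc1NC(=O)C1NCCc2ccccc21`; compound 2 `O=C(Nc1ccccc1O)C1NCCc2ccccc21`; compound 3 `O=C(Nc1ccccc1O)c1nccc2ccccc12`.

In a functional assay on NUGC-3 cells (Homo sapiens) for inhibition, read by sulforhodamine B assay, with a stated time of 48 h (on this read-out lower numbers stand for stronger inhibition of growth and higher numbers for weaker inhibition of growth), compound 1 gives only the assay limit > 10000 nM. In this assay compound 2 likewise gives only the limit > 10000 nM. In this assay compound 3 also gives only the limit > 10000 nM.

Compound 2 and compound 1 differ in one place: methyl in place of hydrogen on an oxygen on an aromatic ring. The step that the two limits leave unreadable from compound 2 to compound 1 cannot be read, because of the limit of > 10000 nM in this assay, at which 3 of the 3 values shown sit. Compound 3 and compound 2 carry the same amide and the same hydroxy-bearing ring, but the difference between their two cores is not broken down here.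

Compound 4 `COc1ccccc1NC(=O)c1nccc2ccccc12` is not yet measured. It differs from compound 3 by methyl in place of hydrogen on an oxygen on an aromatic ring, which is the same change, at the same kind of place, as that from compound 2 to compound 1. Since the measured step gives no readable size, and since compound 3 itself sits only at the limit > 10000 nM, the expectation for compound 4 rests on that limit alone: compound 4 is expected to give about 15000 nM in this assay, between 8000 nM and 40000 nM, most likely again as a limit rather than a number. The step expected from compound 3 to compound 4 is therefore a step that the limit leaves unreadable from compound 3 to compound 4, essentially no change.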

Compound 4, concentration for 50% growth inhibition: > 10000 nM
Compound 4: a limit, no number (the forecaster's own chance of this, stated with the estimate: 85%); the middle value is on the limit's open side.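

Among these compounds, neither the step from compound 3 to compound 4 nor the one from compound 2 to compound 1 can be read, because both compounds of each pair give only a limit and no number: the limit of > 10000 nM in this assay, at which 4 of the 4 values shown sit. Going by these compounds, whether hydroxy to methoxy changes growth inhibition at all in this assay stays open for both pairs, as does the size of any such change.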